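A second bromo group on compound 3

A few compounds are considered here, and "the series" means these few. Any claim that something is new, unique, unknown or untested is made for them only; others in the source may bear on it.

Results in a functional assay on PC-3 cells (Homo sapiens) for cytotoxicity, read by MTT assay, with a stated time of 72 h (a higher number here means a weaker inhibitor, a lower number a stronger inhibitor), for the measured compounds
compound 1 `N#Cc1ccc(/C=N/NC(=O)Nc2cc3c(Nc4ccc(F)c(Cl)c4)ncnc3cc2O[C@H]2CCOC2)cc1` gives 28100 nM
compound 2 `COc1ccc(/C=N/NC(=O)Nc2cc3c(Nc4ccc(F)c(Cl)c4)ncnc3cc2O[C@H]2CCOC2)cc1` gives 34100 nM
compound 3 `O=C(N/N=C/c1ccc(O)c(Br)c1)Nc1cc2c(Nc3ccc(F)c(Cl)c3)ncnc2cc1O[C@H]1CCOC1` gives 5230 nM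

Of the three, compound 3 (5230 nM) has the lowest number, which makes it the strongest inhibitor here. Two steps lead to it, a 5.4-fold lower number from compound 1 to compound 3 (0.73 log units; beyond the scatter) and a 6.5-fold lower number from compound 2 to compound 3 (0.81 log units; beyond the scatter) and each replaces a whole substituted phenyl group. By contrast, a 1.2-fold higher number from compound 1 to compound 2 (0.08 log units; within the scatter) and so shows no real difference.

Compound 4 `O=C(N/N=C/c1cc(Br)c(O)c(Br)c1)Nc1cc2c(Nc3ccc(F)c(Cl)c3)ncnc2cc1O[C@H]1CCOC1` keeps the shared core and changes one spot: bromo in place of hydrogen on an aromatic carbon turning 3-bromo-4-hydroxyphenyl into 3,5-dibromo-4-hydroxyphenyl, with the new bromo ortho to a hydroxy group.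

Among the compounds with values here, no measured step adds a bromo group on its own, so the two modest steps to compound 3 are only a weak guide. They show that the number can move when this group changes, but not what a second bromo does. A small downward move is therefore expected, and it may not exceed the scatter. The expected step is a 1.3-fold lower number from compound 3 to compound 4 (0.12 log units; within the scatter) in this assay as a rough estimate. Compound 4 is estimated at 4000 nM with an expected range from 1500 nM to 12000 nM on this measure.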

Compound 4, half-maximal inhibitory concentration: 6160 nM
Estimate against measurement, compound 4: 1.5-fold (0.19 log units) below, and the stated range covers the measured number.
By their numbers in this assay, from the lowest: compounds 3 and 4 (each within the scatter of the next); then compounds 1 and 2 (each within the scatter of the next).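

Placing a second bromo group ortho to a hydroxy group leaves the number unchanged in this assay (a 1.2-fold higher number from compound 3 to compound 4 (0.07 log units; within the scatter)), so this position takes a bromo group without losing the gain already seen with compound 3. The 3,5-dibromo-4-hydroxyphenyl group also keeps a clear lead over the two simpler rings, both over 4-methoxyphenyl (a 5.5-fold lower number from compound 2 to compound 4 (0.74 log units; beyond the scatter)) and over 4-cyanophenyl (a 4.6-fold lower number from compound 1 to compound 4 (0.66 log units; beyond the scatter)). No measurement is available to explain why these numbers fall where they do.

The compounds shown leave open whether a methyl group or an amine at this same position would also leave the number unchanged. They also cannot separate the part played by the hydroxy group from that of the bromo groups in the lower numbers of compound 3 and compound 4.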